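Benzylamino in place of dimethylamino: notes toward compound 4

This account rests on a few compounds, and the source may have more. Where it says the series, first, only, none or still open, it means among the compounds named here.

Three compounds carry numbers in an in vitro functional assay on B300-19 cells for antagonist activity at C-C chemokine receptor type 4 (Homo sapiens), read by GTPgammaS binding, tested at 1 uM; a higher number here means more inhibition at the concentration tested (going by the name of the read-out), a lower number less inhibition. Compound 1 `COc1cc2nc(NCc3ccccc3)nc(NC3CCCCCC3)c2cc1OC` gives 13% and compound 2 `c1ccc2c(NC3CCCCCC3)nc(N3CCC(N4CCCC4)CC3)nc2c1` gives 10%; these two lie within the scatter of each other. For compound 3 `COc1cc2nc(N3CCC(N4CCCC4)CC3)nc(N(C)C)c2cc1OC` the assay reports only a limit, < 0%. That reading is the limit of < 0% in this assay, at which 1 of the 3 values shown sits, so compound 3 has no number of its own. Compound 4 `COc1cc2nc(N3CCC(N4CCCC4)CC3)nc(NCc3ccccc3)c2cc1OC` is not yet measured and differs from compound 3 by benzylamino in place of dimethylamino on an aromatic carbon. Among the compounds with values here, no measured pair isolates this change. Because compound 1 gives 13% and compound 2 gives 10%, both modest, the expected step of a number at least 10 percentage points higher from compound 3 to compound 4 (that floor lies within the scatter) is small, upward if at all, and may not exceed the scatter. Compound 4 is expected to give about 10%, between -5% and 25%, in this assay.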

Compound 4, a percentage reported as inhibition, at one concentration (the size of the read-out at that concentration, not a potency): 10%
Estimate against measurement, compound 4: no gap at the digits printed, and the stated range covers the measured number.
By their numbers in this assay, from the lowest: compounds 2, 4 and 1 (each within the scatter of the next). At a limit, below all of these: compound 3.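

The change shows in this assay as a number at least 10 percentage points higher from compound 3 to compound 4 (that floor lies within the scatter), the first step read at this position, on the aromatic carbon next to the ring nitrogen. With benzylamino there, compound 4 gives 10%, a number of its own but a modest one. Compound 3 stands at a limit, so the size of the step remains unknown: the limit of < 0% in this assay, at which 1 of the 4 values shown sits.

Still open, as far as these compounds go, is whether another amine at this position, such as phenethylamino with its longer chain, would give a reading clearly beyond the scatter. The same holds for benzylamino carrying a carboxylic acid on its ring.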